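Swapping the piperazine aryl cap for a carbamate in a chalcone series

The source may report more compounds than this note shows. Statements on the series, on what has been measured and on what is new or still open speak of the compounds shown alone.

Measured compounds:
Compound 1 `CCCCCCCCn1cc(/C=C/C(=O)c2ccc(NC(=O)CN3CCN(c4ccccc4F)CC3)cc2)nn1` — 60300 nM
Compound 2 `CCCCCCCCCCn1cc(/C=C/C(=O)c2ccc(NC(=O)CBr)cc2)nn1` — 8680 nM

Two members of this series have been tested in a functional assay on SK-N-SH cells (Homo sapiens) for inhibition, read by MTT assay; on this read-out lower numbers stand for stronger inhibition and higher numbers for weaker inhibition. Compound 1 gives 60300 nM and stands at the higher of the two numbers; compound 2 gives 8680 nM, a lower number whose gap to compound 1 lies beyond the usual scatter. Compound 3 `CCCCCCCCn1cc(/C=C/C(=O)c2ccc(NC(=O)CN3CCN(C(=O)OC(C)(C)C)CC3)cc2)nn1` has not yet been measured. It shares the core of compound 1 and differs from it in one place: tert-butoxycarbonyl in place of 2-fluorophenyl on an amine nitrogen in a ring. Going by the values given here, no measured pair in this set isolates such a change, so the size of the step cannot be read off from other compounds. With only the value of compound 1 as an anchor, the account expects a step from compound 1 to compound 3 of about a 1.2-fold higher number from compound 1 to compound 3 (0.06 log units; within the scatter) in this assay, which is no change beyond the scatter. For compound 3 the estimated value in this assay is 70000 nM, within a range from 20000 nM to 200000 nM.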

Compound 3, half-maximal inhibitory concentration: 38000 nM
Beside the measured number, compound 3's estimate is 1.8-fold (0.27 log units) above it; the range from low to high includes it.
By their numbers in this assay, from the lowest: compound 2; then compounds 3 and 1 (each within the scatter of the next).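

In this assay, tert-butoxycarbonyl in place of 2-fluorophenyl on the amine nitrogen in the ring gives a 1.6-fold lower number from compound 1 to compound 3 (0.20 log units; within the scatter) and so no change that can be told from repeated measurement. Going by these compounds alone, at this position, then, the six-membered aromatic ring can leave and a group with no ring and two hydrogen-bond acceptors can enter without a step beyond the scatter, which the earlier compounds could not show. Nothing available on the compounds explains this result.

The compounds shown leave open whether a free amine hydrogen, an acetyl group or a carboxylic acid on the same nitrogen would move the number beyond the scatter. They also leave open whether the same swap would behave alike on the shared core with a longer chain.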